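A few compounds are considered here, and "the series" means these few. Any claim that something is new, unique, unknown or untested is made for them only; others in the source may bear on it.

Of the compounds shown here, two built on a shared core have so far been measured in a functional assay on KB cells (Homo sapiens) for cytotoxicity, read by MTT assay, with a stated time of 72 h; on this read-out higher numbers stand for weaker inhibition and lower numbers for stronger inhibition. Compound 1, `COCNc1n[n+]([O-])c2ccccc2[n+]1[O-]`, carries a methoxymethyl group; in this assay compound 1 gives 9070 nM. Compound 2, `CC(OCNc1n[n+]([O-])c2ccccc2[n+]1[O-])c1ccccc1`, carries a larger group; in this assay compound 2 gives 14000 nM. Compound 1 has the lower of the two numbers, yet the gap to compound 2 lies within the scatter of repeated measurements, so the two cannot be told apart on these figures.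

Compound 3, `CCCOCNc1n[n+]([O-])c2ccccc2[n+]1[O-]`, is not yet measured. It differs from compound 1 in one place: ethyl in place of hydrogen on a saturated chain carbon bound to an oxygen on a saturated carbon. Among the measured compounds shown here, no measured pair here shows the effect of such a lengthening, so nothing in the data sets its size. What compound 1 and compound 2 do show is that a change in this part of the molecule can leave the number within the scatter, and that is the expectation here. The expected step is a 1.1-fold lower number from compound 1 to compound 3 (0.05 log units; within the scatter), no larger than the scatter. For compound 3 in this assay the estimate is 8000 nM, with a range from 3000 nM to 20000 nM.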

Compound 3, half-maximal inhibitory concentration: 10200 nM
Estimate against measurement, compound 3: 1.3-fold (0.11 log units) below, and the stated range covers the measured number.
By their numbers in this assay, from the lowest: compounds 1, 3 and 2 (each within the scatter of the next).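

Among the compounds shown here, compound 3 provides the first readable step at this position: in this assay, going from methoxymethyl to propoxymethyl, with ethyl in place of hydrogen on a saturated chain carbon bound to an oxygen on a saturated carbon, gives a 1.1-fold higher number from compound 1 to compound 3 (0.05 log units; within the scatter) as the measured difference. At this position, then, adding 2 carbon heavy atoms with no ring does not shift the number beyond what repeated measurements of the same compound could produce, although this single step cannot establish a trend with chain length. No independent measurement is available to explain this result.

Going by these compounds, it remains open whether a longer chain, such as butoxymethyl, or a chain ending in an amine or a carboxylic acid would also keep the number within the scatter of compound 1 or would move it clearly in either direction. All three compounds share the same core, so these numbers also leave open how a change to the core, such as a chlorine on its benzene-like part, would compare with changes to this side chain.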